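The compounds below may be only part of what the source reports. "The series", "measured", "known", "first", "only" and "open" are said of these compounds alone.

Compound 2 `COC(=O)c1cccc(CC[C@H]([C@H](C)O)n2cnc3c(N)ncnc32)c1` is measured in an assay on isolated protein for inhibition of adenosine deaminase (Bos taurus), with a stated time of 5 min (on this read-out lower numbers stand for stronger inhibition and higher numbers for weaker inhibition), where compound 2 gives 2.2 nM, the higher of the two numbers shown; compound 1 `C[C@H](O)[C@@H](CCC1CCCCC1)n1cnc2c(N)ncnc21` gives 1.9 nM in this assay, and the gap between the two lies within the usual scatter. Compound 3 `C[C@H](O)[C@@H](CCc1cccc(C(N)=O)c1)n1cnc2c(N)ncnc21` is not yet measured. It differs from compound 2 by amino in place of methoxy on a carbonyl carbon. For the measured compounds named here, no measured pair shows this change, so no step is known for it; the two measured compounds give nearly the same number although they differ well away from the shared core. The step from compound 2 to compound 3 is expected to be small, a 1.1-fold higher number from compound 2 to compound 3 (0.06 log units; within the scatter), in either direction or none beyond the scatter. Compound 3 is therefore estimated at 2.5 nM, most likely between 1 nM and 6 nM.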

Compound 3, inhibition constant: 2.9 nM
The estimate for compound 3 lay 1.2-fold (0.06 log units) below the measured number, and the stated range covers the measured number.
By their numbers in this assay, from the lowest: compounds 1, 2 and 3 (each within the scatter of the next).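

Putting amino in place of methoxy on the carbonyl carbon gives a 1.3-fold higher number from compound 2 to compound 3 (0.12 log units; within the scatter) in this assay. For the compounds shown here, this is the first pair here that differs in only one place, and although the change swaps a hydrogen-bond acceptor for a hydrogen-bond donor, the two numbers cannot be told apart. No measurement shown offers an explanation for this result.

As far as these compounds go, whether a hydroxyl or a methylamino group on this carbonyl carbon would also give a similar number remains open. So does whether the same change would read alike on a longer chain.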